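Swapping 3-nitrophenyl for 4-nitrophenyl in compound 2

A few compounds are considered here, and "the series" means these few. Any claim that something is new, unique, unknown or untested is made for them only; others in the source may bear on it.

Of the compounds shown here, two with a shared core have been measured in a functional assay on MCF7 cells (Homo sapiens) for cytotoxicity, read by MTT assay, with a stated time of 96 h; on this read-out higher numbers stand for weaker inhibition and lower numbers for stronger inhibition. Compound 1 (`COc1cc(C(=O)c2cn(-c3cccc(C)c3)cc2-c2ccc([N+](=O)[O-])cc2)cc(OC)c1OC`) gives 780 nM, and compound 2 (`COc1cc(C(=O)c2cn(-c3cccc(N)c3)cc2-c2cccc([N+](=O)[O-])c2)cc(OC)c1OC`) gives 510 nM. These two numbers lie within the usual scatter of each other, so compound 2 stands level with compound 1 on the data so far. Compound 3 (`COc1cc(C(=O)c2cn(-c3cccc(N)c3)cc2-c2ccc([N+](=O)[O-])cc2)cc(OC)c1OC`) keeps the 3-aminophenyl group of compound 2 and carries 4-nitrophenyl in place of 3-nitrophenyl on an aromatic carbon. Within the data shown here, no measured pair shows this change alone. Compound 1 carries 4-nitrophenyl at the same place but has no 3-aminophenyl group, and its 780 nM gives the only hint of how that group reads in this assay. On that limited basis, no step beyond the scatter is expected in either direction. The expected change is a 1.1-fold lower number from compound 2 to compound 3 (0.03 log units; within the scatter). For compound 3 the estimated value is 480 nM, with an expected range of 130 nM to 1500 nM.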

Compound 3, half-maximal inhibitory concentration: 110 nM
Beside the measured number, compound 3's estimate is 4.4-fold (0.64 log units) above it, outside the stated range (below it).
By their numbers in this assay, from the lowest: compound 3; then compounds 2 and 1 (each within the scatter of the next).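

With the 3-aminophenyl group held fixed, 4-nitrophenyl in place of 3-nitrophenyl gives a 4.6-fold lower number from compound 2 to compound 3 (0.67 log units; beyond the scatter) in this assay, so at this place on the five-membered aromatic ring, two groups with the same atoms joined differently do not read alike. Compound 1 and compound 2 differ in two places, so amino in place of methyl on an aromatic carbon could not be read from them. Among these compounds, compound 3 gives the first reading of this change with 4-nitrophenyl held fixed, a change that gives a 7.1-fold lower number from compound 1 to compound 3 (0.85 log units; beyond the scatter). Nothing at hand accounts for either step.

The nitrophenyl step is known only alongside the 3-aminophenyl group, and the amino step only alongside 4-nitrophenyl, so the compounds shown leave open whether either step would hold with the other group changed. They also leave open how a 4-cyanophenyl or 4-methoxyphenyl group would read in place of 4-nitrophenyl, and how a hydroxyl or a dimethylamino group would read in place of amino.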